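A few compounds are considered here, and "the series" means these few. Any claim that something is new, unique, unknown or untested is made for them only; others in the source may bear on it.

Compounds measured in a functional assay, with a stated time of 10 min; on this read-out lower numbers stand for stronger inhibition and higher numbers for weaker inhibition:
compound 1, `CCOC(=O)c1cnn(-c2nc(-c3ccc(Cl)cc3)c(C#N)c(=O)n2C)c1N`, gives 94 ug/mL;
compound 2, `Cn1c(NN)nc(-c2ccc(Cl)cc2)c(C#N)c1=O`, gives 41 ug/mL;
compound 3, `CSc1nc(-c2ccc(N(C)C)cc2)c(C#N)c(=O)n1C`, gives 84 ug/mL.

Compound 3 stands second highest of the three. Its nearest neighbour is compound 1, whose value lies within the scatter of repeated measurements, so the two cannot be ordered. Compound 2 stands furthest away, with a lower number that lies beyond the scatter.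

Compound 4, `CN(C)c1ccc(-c2nc(NN)n(C)c(=O)c2C#N)cc1`, has not yet been measured in this assay. It differs from compound 3 in one place: aminoamino in place of methylsulfanyl on an aromatic carbon. Within the data shown here, no measured pair shows this change on a shared core. Among the measured compounds shown here, the only compound carrying aminoamino, compound 2, gives the lowest number, so a modest downward step is expected, but it may well fall within the scatter. The estimated step is a 1.7-fold lower number from compound 3 to compound 4 (0.23 log units; within the scatter). Compound 4 is expected to give 50 ug/mL, within a range from 20 ug/mL to 130 ug/mL.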

Compound 4, half-maximal inhibitory concentration: 66 ug/mL
Compound 4: the middle estimate sits 1.3-fold (0.12 log units) below what was measured, within the range that was stated.
By their numbers in this assay, from the lowest: compounds 2, 4, 3 and 1 (each within the scatter of the next, the first and the last beyond it).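

In this assay, aminoamino in place of methylsulfanyl on the aromatic carbon between two ring nitrogen atoms gives a 1.3-fold lower number from compound 3 to compound 4 (0.10 log units; within the scatter) and so, on a shared core, this change stays inside the scatter. With aminoamino held in place, dimethylamino in place of chloro gives a 1.6-fold higher number from compound 2 to compound 4 (0.21 log units; within the scatter) and this step also stays inside the scatter. No measurement here offers an explanation for either step.

The compounds shown leave open whether a primary amine, a morpholine or a longer alkyl chain at this position would shift the number beyond the scatter.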